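Replacing the Ether Chain with a Hydroxyphenyl Group

This account rests on a few compounds, and the source may have more. Where it says the series, first, only, none or still open, it means among the compounds named here.

Compound 3 `CCOC(C)COC1CCN(c2nc(N)c3cc(OC)c(OC)cc3n2)CC1` gives 0.99 nM in an assay on brain for displacement of a labelled ligand from Adrenergic receptor alpha-1 (Rattus norvegicus); a higher number here means a weaker inhibitor, a lower number a stronger inhibitor. Of the three compounds measured it has the lowest number, yet compound 2 `COc1cc2nc(N3CCC(OCC(C)OC)CC3)nc(N)c2cc1OC` with 1.41 nM and compound 1 `CCOCCOC1CCN(c2nc(N)c3cc(OC)c(OC)cc3n2)CC1` with 1.81 nM both stand within the scatter of it, so no order among them can be claimed. The step of a 1.8-fold lower number from compound 1 to compound 3 (0.26 log units; within the scatter) and the step of a 1.4-fold lower number from compound 2 to compound 3 (0.15 log units; within the scatter) both alter the saturated chain carbon bound to an oxygen on a saturated carbon, and the step of a 1.3-fold lower number from compound 1 to compound 2 (0.11 log units; within the scatter) is equally flat; every variation of the chain so far has left the number within the scatter.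

Compound 4 `COc1cc2nc(N3CCC(OCC(O)c4ccccc4)CC3)nc(N)c2cc1OC` differs from compound 3 at that same place: hydroxy(phenyl)methyl in place of 1-ethoxyethyl on a saturated chain carbon bound to an oxygen on a saturated carbon. Going by the values given here, this is a larger change than any of the measured ones, as an aromatic ring and a hydroxyl enter where only an ether chain was varied before, and no measured compound carries a ring at this position. The three flat steps suggest that the chain tolerates change, but they give no guide for a ring. The step of a 1.5-fold higher number from compound 3 to compound 4 (0.18 log units; within the scatter) is therefore expected to be small, in no certain direction, with a wide margin. Compound 4 is expected to give 1.5 nM, between 0.4 nM and 6 nM.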

Compound 4, inhibition constant: 0.15 nM
Compound 4: middle estimate off by 10-fold (1.00 log units), on the high side; the measured number lies below the stated range.
By their numbers in this assay, from the lowest: compound 4; then compounds 3, 2 and 1 (each within the scatter of the next).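

Going by these compounds alone, at a saturated chain carbon bound to an oxygen on a saturated carbon, the ether chains had given only steps within the scatter in this assay, whereas hydroxy(phenyl)methyl gives the first steps beyond it (a 6.6-fold lower number from compound 3 to compound 4 (0.82 log units; beyond the scatter)) and (a 9.4-fold lower number from compound 2 to compound 4 (0.97 log units; beyond the scatter)) and (a 12-fold lower number from compound 1 to compound 4 (1.08 log units; beyond the scatter)). The position therefore does more than tolerate change: the number here can move well beyond the scatter, and compound 4 stands clear of all three ether compounds, making it the strongest of the four in this assay. Nothing measured here accounts for the gain.

Among the compounds shown, the six-membered aromatic ring and the hydrogen-bond donor enter together, so their separate shares in the step remain open, and a 2-phenylethyl chain without the hydroxyl or a 2-hydroxypropyl chain without the ring would be needed to divide them. Also open, from the compounds shown here alone, are an amine in place of the hydroxyl, a fluoro or methoxy group on the phenyl ring, and the two mirror-image forms of the carbon bearing the hydroxyl.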